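A few compounds are considered here, and "the series" means these few. Any claim that something is new, unique, unknown or untested is made for them only; others in the source may bear on it.

Measured in a functional assay on CWR22R cells (Homo sapiens) for antiproliferative activity, read by propidium iodide staining, with a stated time of 96 h; a lower number here means a stronger inhibitor, a higher number a weaker inhibitor:
Compound 1 `CC(O)(CS(=O)(=O)c1cc(C(F)(F)F)cc(C(F)(F)F)c1)C(=O)Nc1ccc(S(F)(F)(F)(F)F)cc1`: 12700 nM
Compound 2 `CC(O)(CS(=O)(=O)c1cccc(C(F)(F)F)c1)C(=O)Nc1cccc(S(F)(F)(F)(F)F)c1`: 24600 nM

Compound 2, at 24600 nM, stands within the usual scatter of compound 1, at 12700 nM, so the two numbers cannot be ranked. Compound 3 `CC(O)(CS(=O)(=O)c1cc(C(F)(F)F)cc(C(F)(F)F)c1)C(=O)Nc1cccc(S(F)(F)(F)(F)F)c1` departs from compound 2 in one place: trifluoromethyl in place of hydrogen on an aromatic carbon, with trifluoromethyl in place of hydrogen on an aromatic carbon. Within the data shown here, no measured pair isolates this change. The nearest guide is compound 1, which also carries this added trifluoromethyl but differs from compound 2 elsewhere too. Compound 1 gives 12700 nM. On that evidence, no change beyond the scatter is expected in this assay, and the direction remains uncertain. The expected outcome is a 1.5-fold lower number from compound 2 to compound 3 (0.19 log units; within the scatter). For compound 3 the estimated value is 16000 nM, with an expected range of 6500 nM to 38000 nM.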

Compound 3, half-maximal inhibitory concentration: 9300 nM
Compound 3: the middle estimate sits 1.7-fold (0.24 log units) above what was measured; the range from low to high includes it.
By their numbers in this assay, from the lowest: compounds 3, 1 and 2 (each within the scatter of the next, the first and the last beyond it).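

In this assay, among these compounds, the step of a 2.6-fold lower number from compound 2 to compound 3 (0.42 log units; beyond the scatter) isolates the added trifluoromethyl on the aromatic carbon for the first time, and it lies beyond the scatter, which the earlier pair could not show. By contrast, exchanging one group of 12 heavy atoms on the amide-type nitrogen for the other gives a 1.4-fold lower number from compound 1 to compound 3 (0.14 log units; within the scatter), so this exchange does not separate the two compounds in this assay. The data shown offer no measurement that accounts for the step.

Going by these compounds, whether another group at this place, such as a nitrile, a methoxy group or an amine, would give a similar step remains open. On these data alone, it is also open whether trifluoromethyl would give the same step with the amide-type nitrogen group of compound 1.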